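This account rests on a few compounds, and the source may have more. Where it says the series, first, only, none or still open, it means among the compounds named here.

Measured compounds:
- compound 1, `Oc1cccc(-c2cc(-c3cccnc3)nc(-c3cccc(Cl)c3)c2)c1`: "not determined" (no result reported)
- compound 2, `Oc1cccc(-c2cc(-c3cccc(Cl)c3)nc(-c3ccco3)c2)c1`: 2530 nM

Compound 2 thus carries the only number shown in this assay; compound 1 stands beside it without one. Compound 3, `Oc1cccc(-c2cc(-c3ccsc3)nc(-c3cccc(Cl)c3)c2)c1`, differs from compound 2 by thiophen-3-yl in place of furan-2-yl on an aromatic carbon. Within the data shown here, no measured pair of this kind is available, so the size of the step rests on expectation alone. Thiophen-3-yl and furan-2-yl are counted alike here, and the expected step of a 1.0-fold lower number from compound 2 to compound 3 (0.01 log units; within the scatter) is therefore taken as no more than the scatter, in either direction. Compound 3 is estimated at 2500 nM, between 1000 nM and 6300 nM.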

Compound 3, half-maximal inhibitory concentration: 3180 nM
Compound 3: the middle estimate sits 1.3-fold (0.10 log units) below what was measured; the range from low to high includes it.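

In an ADME assay on HEK293 cells (Homo sapiens) for cytotoxicity, read by CCK-8 assay and cell counting, with a stated time of 2 days (on this read-out lower numbers stand for stronger inhibition and higher numbers for weaker inhibition), thiophen-3-yl in place of furan-2-yl on the aromatic carbon next to the ring nitrogen gives a 1.3-fold higher number from compound 2 to compound 3 (0.10 log units; within the scatter) and so leaves the number unchanged within the scatter. At this position, exchanging one five-membered aromatic ring for another, with sulfur instead of oxygen as its hetero atom, therefore makes no readable difference. Nothing shown explains this result.

On these data alone, what an amine or a carboxylic acid on this carbon would do remains open. Compound 1 has no reported result, so it offers no further comparison.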